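Three Close Relatives Point to a Flat Expectation

The compounds below may be only part of what the source reports. "The series", "measured", "known", "first", "only" and "open" are said of these compounds alone.

Three measured compounds share one core and differ only in the aromatic group on an amine nitrogen in a ring. In a functional assay on A549 cells (Homo sapiens) for antiproliferative activity, read by MTT assay, with a stated time of 48 h (a higher number here means a weaker inhibitor, a lower number a stronger inhibitor), compound 1 `O=C(/C=C/c1ccc(O)c(O)c1)N1CCN(c2ccc(F)cc2)CC1` gives 1.25 ug/mL, compound 2 `O=C(/C=C/c1ccc(O)c(O)c1)N1CCN(c2ccccc2Cl)CC1` gives 1.44 ug/mL and compound 3 `O=C(/C=C/c1ccc(O)c(O)c1)N1CCN(c2cccc(Cl)c2)CC1` gives 1.29 ug/mL. These three numbers lie within the scatter of one another, so compound 1 holds no real rank among them.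

Compound 4 `COc1cccc(N2CCN(C(=O)/C=C/c3ccc(O)c(O)c3)CC2)c1` has not been measured. It has 3-methoxyphenyl in place of 4-fluorophenyl on an amine nitrogen in a ring.

Three measured swaps at this same place bear on the change. They are a 1.2-fold higher number from compound 1 to compound 2 (0.06 log units; within the scatter), a 1.0-fold higher number from compound 1 to compound 3 (0.01 log units; within the scatter) and a 1.1-fold lower number from compound 2 to compound 3 (0.05 log units; within the scatter). All three stay within the scatter. None of these compounds carries a methoxy group, so the incoming group itself is untested. The nearest guide by name is the 3-chlorophenyl of compound 3, reached by a 1.0-fold higher number from compound 1 to compound 3 (0.01 log units; within the scatter), and on that basis no step beyond the scatter is expected in this assay.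

The estimated step is a 1.0-fold higher number from compound 1 to compound 4 (0.02 log units; within the scatter). For compound 4 the estimated value is 1.3 ug/mL, with an expected range from 0.8 ug/mL to 2.1 ug/mL.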

Compound 4, half-maximal inhibitory concentration: 1.27 ug/mL
Estimate against measurement, compound 4: 1.0-fold (0.01 log units) above; the measured number falls inside the stated range.
By their numbers in this assay, from the lowest: compounds 1, 4, 3 and 2 (each within the scatter of the next).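

For the compounds shown here, the methoxy group is new to this position, and 3-methoxyphenyl is the first group here to carry a hydrogen-bond acceptor, yet in this assay replacing 4-fluorophenyl gives a 1.0-fold higher number from compound 1 to compound 4 (0.01 log units; within the scatter) and stays within the scatter. Putting methoxy in place of chloro on an aromatic carbon gives a 1.0-fold lower number from compound 3 to compound 4 (0.01 log units; within the scatter) and the comparison with the 2-chlorophenyl compound gives a 1.1-fold lower number from compound 2 to compound 4 (0.05 log units; within the scatter) and both of these also stay within the scatter. Across these four compounds, then, fluoro, chloro and methoxy groups on the phenyl ring attached to this amine nitrogen all give values that cannot be told apart in this assay, so the change adds an oxygen-bearing group to a flat set without separating any compound from the others.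

Still open, as far as these compounds go, is whether a quite different group on this nitrogen, such as a carboxylic acid on the phenyl ring, a primary amine on that ring or a plain methyl in place of the whole aromatic group, would produce a step beyond the scatter. No independent measurement is available to explain the flat numbers seen so far.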